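The source may report more compounds than this note shows. Statements on the series, on what has been measured and on what is new or still open speak of the compounds shown alone.

In an ADME assay on microsomes from liver (Mus musculus) for metabolic stability, read by mass spectrometry, with a stated time of 40 min, tested at 1 uM (a lower number here means that less of the compound is left, a higher number that more of the compound is left), compound 1 (`COc1cc(N2CCN(Cc3ccccn3)CC2)ccc1Nc1nc(NC2CCCCC2)c2nc[nH]c2n1`) gives 38% and compound 2 (`COc1cc(N2CCC(CC(=O)N3CCOCC3)CC2)ccc1Nc1nc(NC2CCCCC2)c2nc[nH]c2n1`) gives 61% as the higher of the two numbers, a gap beyond the usual scatter. Compound 3 (`COc1cc(N2CCC(CC(=O)N3CCCC3)CC2)ccc1Nc1nc(NC2CCCCC2)c2nc[nH]c2n1`) has not yet been measured. The change from compound 2 to compound 3 is pyrrolidin-1-yl in place of morpholin-4-yl on a carbonyl carbon. Going by the values given here, no measured pair shows this change, so the expectation rests on the structures alone: a moderate fall in this assay is expected, with the estimated step of a number 16 percentage points lower from compound 2 to compound 3 (beyond the scatter) lying somewhat beyond the scatter. Compound 3 is expected to give 45% (estimated range 28% to 62%).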

Compound 3, percent of the compound remaining: 59%
Estimate against measurement, compound 3: 14 percentage points below; the range from low to high includes it.
By their numbers in this assay, from the lowest: compound 1; then compounds 3 and 2 (each within the scatter of the next).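

Swapping morpholin-4-yl for pyrrolidin-1-yl on this carbonyl carbon gives, in this assay, a number 2 percentage points lower from compound 2 to compound 3 (within the scatter), the first step read at this position. A five-membered ring with 1 hetero atom thus stands here in place of a six-membered ring with 2 hetero atoms without a change beyond the scatter, which the two earlier compounds, differing in more than one place, could not show. Nothing available explains this result. Open, as far as these compounds go, is how this assay responds to piperidin-1-yl, dimethylamino or a carboxylic acid at this position.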